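Cytotoxicity notes: the step from compound 3 to compound 4

This account rests on a few compounds, and the source may have more. Where it says the series, first, only, none or still open, it means among the compounds named here.

Three compounds have entries in an ADME assay on Vero cells (Chlorocebus sabaeus) for cytotoxicity, read by MTT assay, with a stated time of 72 h (a lower number here means that less compound is tolerated, a higher number that more compound is tolerated), and none gives a single number. Compound 1 `O=C(N/N=C/c1ccc([N+](=O)[O-])cc1)c1ccc([N+](=O)[O-])o1` stands as "not determined" (no result reported). Compound 2 `O=C(N/N=C/c1ccc(Cl)cc1)c1ccc([N+](=O)[O-])o1` stands as "not determined" (no result reported). Compound 3 `C/C(=N\NC(=O)c1ccc([N+](=O)[O-])o1)c1ccccc1` reads > 228000 nM, which is a limit of the assay and not a number. Within the data shown here, compound 3 therefore has no exact position, and no step between measured compounds is available for comparison.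

Compound 4 `C/C(=N\NC(=O)c1ccc([N+](=O)[O-])o1)c1ccc(Br)cc1` has not yet been measured. It differs from compound 3 by bromo in place of hydrogen on an aromatic carbon, para to a large group: bromo in place of hydrogen on an aromatic carbon.

The expectation rests only on the limit for compound 3, > 228000 nM. The expected change is an at least 1.5-fold lower number from compound 3 to compound 4 (0.18 log units; that floor lies within the scatter), a modest move toward less compound tolerated, though a result within the scatter or another limit would not be surprising. The estimate for compound 4 is 150000 nM, with an expected range from 40000 nM to 350000 nM.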

Compound 4, half-maximal cytotoxic concentration: > 177000 nM
Compound 4: no number, only a limit (the forecaster's own chance of this, stated with the estimate: 50%); at least 1.1-fold (0.07 log units) between middle value and limit.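

In this assay compound 4 reads > 177000 nM, a limit of the assay and not a number. Compound 3 also stands only as a limit, so no step can be read between compound 3 and compound 4. The compounds shown leave open whether phenyl to 4-bromophenyl changes the half-maximal cytotoxic concentration at all.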